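Dichlorophenyl sulfonamide on a benzoxazole scaffold: an expected inactive

This account rests on a few compounds, and the source may have more. Where it says the series, first, only, none or still open, it means among the compounds named here.

The account follows two aryl sulfonamides built on the same core. Compound 1 `O=S(=O)(Nc1ccc2oc(-c3ccccc3)nc2c1)c1ccccc1F` was tested in an assay on isolated protein for inhibition of malate dehydrogenase, mitochondrial (Sus scrofa), with stated times of 45 min and 30 min (a higher number here means a weaker inhibitor, a lower number a stronger inhibitor), and returned only a limit. In this assay compound 1 gives > 63000 nM, a limit rather than a number. Compound 2 `O=S(=O)(Nc1ccc(-c2nc3ccccc3o2)cc1)c1cccs1` likewise reaches only a limit in this assay, where compound 2 gives > 63000 nM. Within the data shown here, compound 1 therefore stands at the limit alone; the only evidence on the set is the limit of > 63000 nM in this assay, at which 2 of the 2 values shown sit, and no step between measured compounds can be drawn.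

Compound 3 `O=S(=O)(Nc1ccc2oc(-c3ccccc3)nc2c1)c1ccc(Cl)c(Cl)c1` carries the change (3,4-dichlorophenyl in place of 2-fluorophenyl on a sulfonyl sulfur). Among the measured compounds shown here, with no measured step to lean on, the step from compound 1 to compound 3 is expected to be none beyond the scatter, as a step that the limit leaves unreadable from compound 1 to compound 3 expresses. Compound 3 is expected to give about 80000 nM in this assay, within a range from 30000 nM to 250000 nM, most likely again reported as a limit.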

Compound 3, half-maximal inhibitory concentration: > 63000 nM
Compound 3 gave a limit, no number; the forecaster's own chance of this, stated with the estimate: 80%; the middle value lies beyond the limit too.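

Compound 1 and compound 3 each return only a limit in this assay, and the step between them cannot be read. The compounds shown leave open what inhibition, if any, the shared core can reach in this assay, and how the group on the sulfonyl sulfur would shift it.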